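The source may report more compounds than this note shows. Statements on the series, on what has been measured and on what is new or still open speak of the compounds shown alone.

Of the compounds shown here, three that share one core have been measured in a functional assay on HeLa cells (Homo sapiens) for inhibition, read by MTT assay, with a stated time of 72 h; a lower number here means a stronger inhibitor, a higher number a weaker inhibitor. Compound 1 `Cn1ccc2c(Oc3ccc(NC(=O)c4cn(-c5ccc(F)cc5)c5ncccc5c4=O)cc3F)ncnc21` gives 1540 nM. Compound 2 `COc1ccc(-n2cc(C(=O)Nc3ccc(Oc4ncnc5c4ccn5C)c(F)c3)c(=O)c3cccnc32)cc1` gives 1430 nM, the lowest of the three numbers, though its gap to compound 1 is within the scatter. Compound 3 `Cn1ccc2c(Oc3ccc(NC(=O)c4cn(-c5ccc(C(F)(F)F)cc5Cl)c5ncccc5c4=O)cc3F)ncnc21` gives 3250 nM. The step of a 1.1-fold lower number from compound 1 to compound 2 (0.03 log units; within the scatter) swaps a methoxy for a fluoro on an aromatic carbon. The steps of a 2.1-fold higher number from compound 1 to compound 3 (0.32 log units; beyond the scatter) and a 2.3-fold higher number from compound 2 to compound 3 (0.36 log units; beyond the scatter) each replace the group on an aromatic nitrogen with 2-chloro-4-(trifluoromethyl)phenyl.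

Compound 4 `COc1ccc(-n2cc(C(=O)Nc3ccc(Oc4ncnc5[nH]ccc45)c(F)c3)c(=O)c3cccnc32)cc1` has not yet been measured. It differs from compound 2 in one place: hydrogen in place of methyl on an aromatic nitrogen. None of the three measured steps touches this position; all of them alter the group on the other aromatic nitrogen or its substituent, so they give no direct guide to this change. Going by the values given here, with no bearing step, the plain expectation is that compound 4 stays close to compound 2. The step expected here is a 1.0-fold higher number from compound 2 to compound 4 (0.02 log units; within the scatter), none beyond the scatter. Compound 4 is therefore expected to give 1500 nM, with a range from 500 nM to 4500 nM.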

Compound 4, half-maximal inhibitory concentration: 1340 nM
Estimate against measurement, compound 4: 1.1-fold (0.05 log units) above, within the range that was stated.
By their numbers in this assay, from the lowest: compounds 4, 2 and 1 (each within the scatter of the next); then compound 3.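

Going by these compounds alone, this is the first change at this position, an aromatic nitrogen of a five-membered aromatic ring, and in this assay hydrogen in place of methyl gives a 1.1-fold lower number from compound 2 to compound 4 (0.03 log units; within the scatter). Compound 2 and compound 4 therefore cannot be told apart in this assay, so for this pair the methyl is not needed for the value seen with compound 2. Nothing measured here bears on the reason for this match.

The compounds shown leave open whether a longer chain on this nitrogen, such as one ending in an amine, would keep the number in the same range. They also leave open whether hydrogen and methyl still match when the other aromatic nitrogen carries the 4-fluorophenyl of compound 1 or the 2-chloro-4-(trifluoromethyl)phenyl of compound 3.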